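Swapping a chloro for two methyls on the hydrazone aryl

The compounds below may be only part of what the source reports. "The series", "measured", "known", "first", "only" and "open" are said of these compounds alone.

Three compounds share a core and differ only in the aryl ring attached to the carbon that carries a double bond to nitrogen. Compound 1 `Cn1c(=O)c(=O)n(C2CCCC2)c2nc(N/N=C/c3ccc(Cl)cc3)ncc21` gives 8420 nM in a functional assay on PC-3 cells (Homo sapiens) for antiproliferative activity, read by MTT assay (a higher number here means a weaker inhibitor, a lower number a stronger inhibitor), and has the lowest of the three numbers. Compound 2 `Cn1c(=O)c(=O)n(C2CCCC2)c2nc(N/N=C/c3ccc(F)c(Cl)c3)ncc21` gives 8550 nM in this assay, and the step of a 1.0-fold higher number from compound 1 to compound 2 (0.01 log units; within the scatter) lies within the scatter. Compound 3 `COc1cccc(/C=N/Nc2ncc3c(n2)n(C2CCCC2)c(=O)c(=O)n3C)c1` gives 20700 nM in this assay, and the step of a 2.5-fold higher number from compound 1 to compound 3 (0.39 log units; beyond the scatter) is a modest loss, as is a 2.4-fold higher number from compound 2 to compound 3 (0.38 log units; beyond the scatter).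

Compound 4 `Cc1ccc(/C=N/Nc2ncc3c(n2)n(C2CCCC2)c(=O)c(=O)n3C)cc1C` has not yet been measured. It differs from compound 1 in this way: 3,4-dimethylphenyl in place of 4-chlorophenyl on a carbon with a double bond to nitrogen. The two measured steps show that trading one halogen pattern for another on this ring changes little, while a methoxy group on the ring costs a modest amount. Neither step involves methyl groups, so the evidence is indirect. The expectation is a small step, a 1.2-fold higher number from compound 1 to compound 4 (0.07 log units; within the scatter), most likely within the scatter or a slight loss. Compound 4 is therefore estimated at 10000 nM in this assay, with a range from 4000 nM to 25000 nM.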

Compound 4, half-maximal inhibitory concentration: 39000 nM
For compound 4 the middle estimate is 3.9-fold (0.59 log units) below the measured one; the whole stated range lies below it.
By their numbers in this assay, from the lowest: compounds 1 and 2 (each within the scatter of the next); then compounds 3 and 4 (each within the scatter of the next).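

In this assay, the new ring shows that this position does not accept every substituent swap equally: 3,4-dimethylphenyl in place of the halogen-bearing rings gives a modest loss beyond the scatter, both in the step from the chloro ring (a 4.6-fold higher number from compound 1 to compound 4 (0.67 log units; beyond the scatter)) and in the step from the chloro-fluoro ring (a 4.6-fold higher number from compound 2 to compound 4 (0.66 log units; beyond the scatter)). The earlier compounds left open whether the loss seen with 3-methoxyphenyl was particular to that group, but the dimethyl ring lands level with it (a 1.9-fold higher number from compound 3 to compound 4 (0.28 log units; within the scatter)), so across these four compounds the two halogen-bearing rings form one group and the two halogen-free rings form a weaker one, and no compound shown goes against this split. Nothing available here explains why the halogen-free rings do worse at this position.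

The compounds shown do not separate the effect of each methyl, so a ring with a single methyl, or one with a single chlorine in the other ring position named in 3-chloro-4-fluorophenyl, would be needed to tell how much each substituent contributes. They also leave open how rings carrying an amine or a carboxylic acid would behave here.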